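Trimethoxyphenyl to dimethoxyphenyl on the enone arm

The source may hold more compounds than are shown below. What is called first, only, known or untested is meant among the compounds shown, and "the series" means these compounds.

The series is built on one shared core carrying an enone arm and a 3,4,5-trimethoxyphenyl group; compound 1 `COc1cc(/C=C/C(=O)c2cc(-c3cc(OC)c(OC)c(OC)c3)n3nc(-c4ccccc4)cc3n2)cc(OC)c1OC` is the parent of this set. In a functional assay on MDA-MB-231 cells (Homo sapiens) for antiproliferative activity, read by MTT assay, with a stated time of 24 h (a higher number here means a weaker inhibitor, a lower number a stronger inhibitor), compound 1 gives 18400 nM, the highest of the three numbers, though its nearest neighbour, compound 2 `COc1ccc(C(=O)/C=C/c2cc(-c3cc(OC)c(OC)c(OC)c3)n3nc(-c4ccccc4)cc3n2)cc1OC`, gives 18300 nM and the furthest, compound 3 `COc1ccc(-c2cc(C(=O)/C=C/c3cc(OC)c(OC)c(OC)c3)nc3cc(-c4ccccc4)nn23)cc1OC`, gives 16700 nM, both within the scatter of compound 1.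

The next compound, compound 4 `COc1ccc(/C=C/C(=O)c2cc(-c3cc(OC)c(OC)c(OC)c3)n3nc(-c4ccccc4)cc3n2)cc1OC`, follows from compound 1 by hydrogen in place of methoxy on an aromatic carbon.

Within the data shown here, one measured step bears on this change: a 1.1-fold lower number from compound 1 to compound 3 (0.04 log units; within the scatter), the same kind of replacement of a methoxy group by hydrogen on an aromatic carbon. That step stayed within the scatter, and the three measured values sit close together, so no step beyond the scatter is expected here either. The step from compound 1 to compound 4 in this assay is therefore estimated as a 1.0-fold lower number from compound 1 to compound 4 (0.01 log units; within the scatter). Among the measured compounds shown here, for compound 4 the estimate in this assay is 18000 nM, with a likely range from 9000 nM to 36000 nM; the range is kept wide because the single comparable step, a 1.1-fold lower number from compound 1 to compound 3 (0.04 log units; within the scatter), is the only guide.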

Compound 4, half-maximal inhibitory concentration: 14200 nM
Compound 4: the middle estimate sits 1.3-fold (0.10 log units) above what was measured; the range from low to high includes it.
By their numbers in this assay, from the lowest: compounds 4, 3, 2 and 1 (each within the scatter of the next).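

In this assay, among these compounds, the change from 3,4,5-trimethoxyphenyl to 3,4-dimethoxyphenyl on the enone arm gives a 1.3-fold lower number from compound 1 to compound 4 (0.11 log units; within the scatter) and so stays within the scatter, which is the first reading of this replacement on that arm. The earlier step, a 1.1-fold lower number from compound 1 to compound 3 (0.04 log units; within the scatter), made the same replacement on the other trimethoxyphenyl group, so a single methoxy can now be exchanged for hydrogen on either aryl group of compound 1 without a step beyond the scatter, and these two steps are the whole basis for that statement. No measured evidence is at hand to explain the size of either step.

Hydrogen is the only replacement shown at this position, so it remains open whether a hydroxy group, an amine, a fluorine atom or a longer chain such as ethoxy in the same place would give a step beyond the scatter in this assay. Also open, from the compounds shown here alone, is whether taking one methoxy from each aryl group in the same compound would stay within the scatter, or whether the two replacements would together give a larger step.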